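Urea side chain opened again: expectation for compound 4

The compounds below may be only part of what the source reports. "The series", "measured", "known", "first", "only" and "open" are said of these compounds alone.

Measured compounds in a functional assay on A-431 cells (Homo sapiens) for antiproliferative activity, read by sulforhodamine B assay, with a stated time of 72 h; on this read-out higher numbers stand for weaker inhibition and lower numbers for stronger inhibition:
compound 1 `COCCNC(=O)Nc1cc2c(Nc3ccc(F)c(Cl)c3)ncnc2cc1O[C@H]1CCOC1` gives 387 nM
compound 2 `CN(C)CCCNC(=O)Nc1cc2c(Nc3ccc(F)c(Cl)c3)ncnc2cc1O[C@H]1CCOC1` gives 226 nM
compound 3 `O=C(Nc1cc2c(Nc3ccc(F)c(Cl)c3)ncnc2cc1O[C@H]1CCOC1)N1CCC(F)(F)CC1` gives 1860 nM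

All three share one core and differ only in the group attached to the urea carbonyl. Compound 3, which carries the ring, stands at the highest number of the three, that is, it inhibits cell growth least; the steps are a 4.8-fold higher number from compound 1 to compound 3 (0.68 log units; beyond the scatter) and an 8.2-fold higher number from compound 2 to compound 3 (0.92 log units; beyond the scatter), both beyond the scatter. The step of a 1.7-fold lower number from compound 1 to compound 2 (0.23 log units; within the scatter) lies within the scatter, so the two open-chain compounds cannot be ranked against each other.

Compound 4 `COC(=O)/C=C/CNC(=O)Nc1cc2c(Nc3ccc(F)c(Cl)c3)ncnc2cc1O[C@H]1CCOC1` is not yet measured. From compound 3 the change is (3-(methoxycarbonyl)prop-2-en-1-yl)amino in place of 4,4-difluoropiperidin-1-yl on a carbonyl carbon. It therefore undoes the kind of change that raised the number in both measured steps, and returns to an open-chain substituent of the same size as in compound 1, though with a methoxycarbonyl alkene rather than a methoxy ending. Because of a 4.8-fold higher number from compound 1 to compound 3 (0.68 log units; beyond the scatter) and an 8.2-fold higher number from compound 2 to compound 3 (0.92 log units; beyond the scatter), a step downward beyond the scatter is expected, estimated as a 4.4-fold lower number from compound 3 to compound 4 (0.65 log units; beyond the scatter) in this assay. For compound 4 the expected value is 420 nM, with a range from 150 nM to 1200 nM.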

Compound 4, half-maximal inhibitory concentration: 1410 nM
Compound 4: the middle estimate sits 3.4-fold (0.53 log units) below what was measured, and the stated range ends below it.
By their numbers in this assay, from the lowest: compounds 2 and 1 (each within the scatter of the next); then compounds 4 and 3 (each within the scatter of the next).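

In this assay the open chain of compound 4 gives a 1.3-fold lower number from compound 3 to compound 4 (0.12 log units; within the scatter), so replacing the 4,4-difluoropiperidin-1-yl ring with (3-(methoxycarbonyl)prop-2-en-1-yl)amino, which also restores the hydrogen-bond donor on that nitrogen, brings no change that can be told from the scatter. Opening the ring is therefore not enough on its own at this carbonyl carbon: 2-(methoxycarbonyl)ethenyl in place of 2-(dimethylamino)ethyl gives a 6.2-fold higher number from compound 2 to compound 4 (0.80 log units; beyond the scatter), and in place of methoxymethyl it gives a 3.6-fold higher number from compound 1 to compound 4 (0.56 log units; beyond the scatter), which shows that the make-up of the open chain matters and not only the absence of a ring. Nothing measured here explains why these chains differ.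

Going by these compounds, it remains open whether the loss comes from the methyl ester or from the double bond, which a saturated chain with the same ester, or a carboxylic acid in place of the ester, would help to separate. On these data alone, it is also open whether a ring can match the open chains of compound 1 and compound 2 once it carries an amine, as 4-(dimethylamino)piperidin-1-yl does.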